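Shrinking the ring on the amine of compound 1

The source may report more compounds than this note shows. Statements on the series, on what has been measured and on what is new or still open speak of the compounds shown alone.

Measured compounds: compound 1 `Cn1cc(-c2ccc3nnc(Sc4ccc5ncc(NC6CCOC6)cc5c4)n3c2)cn1` gives 0.05 h in an ADME assay on cytosol from liver for pharmacokinetics, with aldehyde oxidase 1 (Macaca fascicularis) as the target, read by LC-MS, with a stated time of 120 min, tested at 1 uM; a lower number here means that the compound disappears faster, a higher number that the compound lasts longer; compound 2 `Cn1cc(-c2ccc3nnc(Sc4ccc5ncc(NCC6CCOC6)cc5c4)n3c2)cn1` gives 2.4 h.

Compound 1 has the lowest number of the two. Within the data shown here, the only measured step is a 48-fold higher number from compound 1 to compound 2 (1.68 log units; beyond the scatter), and it adds a carbon between the nitrogen and the ring rather than changing the ring itself, so it bears only loosely on the new change. Compound 3 `Cn1cc(-c2ccc3nnc(Sc4ccc5ncc(NC6COC6)cc5c4)n3c2)cn1` differs from compound 1 by oxetan-3-yl in place of oxolan-3-yl on a nitrogen on an aromatic ring. Among the measured compounds shown here, with no step on ring size to draw on, compound 3 is expected to stay near compound 1, within the scatter, as a 1.4-fold higher number from compound 1 to compound 3 (0.15 log units; within the scatter). The estimate for compound 3 is 0.07 h, between 0.02 h and 0.3 h.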

Compound 3, half-life: 0.05 h
For compound 3 the middle estimate is 1.4-fold (0.15 log units) above the measured one; the range from low to high includes it.
By their numbers in this assay, from the lowest: compounds 1 and 3 (each within the scatter of the next); then compound 2.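

In this assay, replacing oxolan-3-yl with oxetan-3-yl on this nitrogen gives no change at the digits printed from compound 1 to compound 3 (within the scatter) and so shows that these two ring sizes do not separate the compounds. The other new step is a 48-fold lower number from compound 2 to compound 3 (1.68 log units; beyond the scatter) and leaves compound 2 as the only one of the three set apart, carrying (oxolan-3-yl)methyl. Nothing measured here gives a reason for these numbers.

As far as these compounds go, whether the added carbon would have the same effect on a smaller ring remains open. (Oxetan-3-yl)methyl on the same nitrogen would test this, and a longer chain such as 2-(oxolan-3-yl)ethyl would show whether further carbons matter.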